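The source may hold more compounds than are shown below. What is called first, only, known or untested is meant among the compounds shown, and "the series" means these compounds.

Measured compounds:
compound 1 `COc1ccc(N2COc3ccc(C(=O)/C=C/c4ccccc4Cl)cc3C2)cc1` — 63.4%
compound 2 `COc1ccc(/C=C/C(=O)c2ccc3c(c2)CN(c2ccc(OC)cc2)CO3)cc1` — 61.2%
compound 3 `COc1ccc(N2COc3ccc(C(=O)/C=C/c4ccc(Cl)cc4)cc3C2)cc1` — 67.4%

Of the compounds shown here, three sharing one core have been tested in a functional assay on the whole organism (strain Wistar) for inhibition, with Rattus norvegicus as the target, read by paw edema, with a stated time of 3 h, at a dose of 20 mg/kg by the oral route; on this read-out lower numbers stand for less inhibition and higher numbers for more inhibition at the one dose given (going by the name of the read-out). Compound 2 gives the smallest of the three numbers, but neither gap is meaningful: a number 2.2 percentage points lower from compound 1 to compound 2 (within the scatter) and a number 6.2 percentage points higher from compound 2 to compound 3 (within the scatter) both fall within the scatter of the assay, so the three compounds cannot be told apart on this read-out.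

Compound 4 `COc1ccc(/C=C/C(=O)c2ccc3c(c2)CN(c2ccc(C)cc2)CO3)cc1` differs from compound 2 in one place: methyl in place of methoxy on an aromatic carbon. Among the compounds with values here, no measured step swaps exactly these two groups. The closest comparison is the exchange at the same aromatic carbon between compound 2 and compound 3, where chloro replaced methoxy and the result was a number 6.2 percentage points higher from compound 2 to compound 3 (within the scatter). The other two steps, which change the whole aromatic group on the double-bonded chain carbon, gave a number 2.2 percentage points lower from compound 1 to compound 2 (within the scatter) and a number 4 percentage points higher from compound 1 to compound 3 (within the scatter). Within the data shown here, every variation seen at this position so far has stayed within the scatter.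

On that basis the step to compound 4 is expected to be a number 1.8 percentage points higher from compound 2 to compound 4 (within the scatter), nothing beyond the scatter in either direction. For compound 4 in this assay the estimate is 63%, with a range from 53% to 73%.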

Compound 4, a percentage reported as inhibition, in the whole organism at one dose (the size of the read-out at that dose, not a potency): 70.4%
Beside the measured number, compound 4's estimate is 7.4 percentage points below it, and the stated range covers the measured number.
By their numbers in this assay, from the lowest: compounds 2, 1, 3 and 4 (each within the scatter of the next).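

The step to methyl, a number 9.2 percentage points higher from compound 2 to compound 4 (within the scatter), is the first change shown in the group that compounds 1, 2 and 3 all carry unchanged, the 4-methoxyphenyl on the shared core; the other 4-methoxyphenyl of compound 2, the one exchanged in the earlier steps, stays in place in compound 4. So the read-out in this assay has now been probed at a second site, and going from 4-methoxyphenyl to 4-methylphenyl there, with one heavy atom fewer and one hydrogen-bond acceptor fewer, leaves compounds 2 and 4 indistinguishable. Nothing available explains the outcome of this exchange.

On these data alone, with a single exchange at this site, it remains open whether any group there can move the read-out beyond the scatter, for instance an amine, a carboxylic acid or a longer chain such as butyl in place of the methyl. It is also open whether the two aromatic groups act independently, since the compounds shown vary only one of them at a time from compound 2, and each result comes from one dose.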